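Dropping the ortho fluorine from a biphenyl sulfonamide

The compounds below may be only part of what the source reports. "The series", "measured", "known", "first", "only" and "open" are said of these compounds alone.

The series is followed in a functional assay on DLD-1 cells (Homo sapiens) for antiproliferative activity, read by CellTiter-Glo, with a stated time of 72 h; on this read-out higher numbers stand for weaker inhibition and lower numbers for stronger inhibition. Among the compounds with values here, compound 2 `CC1CCN(C2CCN(S(=O)(=O)c3cccc(-c4ccccc4F)c3)CC2)CC1` is the one member with a number in this assay, giving 10 nM. The other two values shown are limits of the assay rather than numbers. Compound 1 `CCc1ccc(S(=O)(=O)N2CCC(N3CCC(C)CC3)CC2)cc1` returns a limit of the assay, > 5000 nM. Compound 3 `Cc1cc(C)c(S(=O)(=O)N2CCC(C(=O)N3CCC(C)CC3)CC2)c(C)c1` likewise returns a limit, > 5000 nM. Compound 2 therefore stands alone with a measured value, set against (the limit of > 5000 nM in this assay, at which 2 of the 3 values shown sit).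

The unmeasured compound 4 `CC1CCN(C2CCN(S(=O)(=O)c3cccc(-c4ccccc4)c3)CC2)CC1` differs from compound 2 in one place: hydrogen in place of fluoro on an aromatic carbon. Within the data shown here, no step between two measured compounds is available to calibrate a change of this kind, so the expectation rests on the single number for compound 2 and on the size of the change, a single fluorine leaving and a hydrogen entering on a ring that is otherwise kept. On that basis compound 4 is expected to stay close to compound 2, with a step from compound 2 to compound 4 of a 2.0-fold higher number from compound 2 to compound 4 (0.30 log units; within the scatter), a small shift toward weaker inhibition at most, within or barely beyond the usual scatter. Compound 4 is estimated at 20 nM, in a range from 6 nM to 60 nM.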

Compound 4, half-maximal inhibitory concentration: 2 nM
Beside the measured number, compound 4's estimate is 10-fold (1.00 log units) above it, outside the stated range (below it).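

In this assay, within the data shown here, the step of a 5.0-fold lower number from compound 2 to compound 4 (0.70 log units; beyond the scatter) is the first reading of any change at a single place, since the earlier compounds offered only one number and no pair to compare. It shows that the fluoro group on this aromatic carbon is not required for activity here, and that going from 2-fluorophenyl to phenyl moves the number toward stronger inhibition by more than the scatter. Nothing shown accounts for the direction of this step.

From the compounds shown here alone, what remains open is whether hydrogen is the best choice on this aromatic carbon, or whether a chloro, a methyl or a methoxy group there would read like the fluoro group of compound 2 or like the hydrogen of compound 4. Going by these compounds, it is also open whether a fluoro group on another carbon of the same ring would carry the same penalty, and how an amine or a carboxylic acid on that phenyl ring would read.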